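The source may hold more compounds than are shown below. What is called first, only, known or untested is meant among the compounds shown, and "the series" means these compounds.

Compound 1 `O=C(/C=C/c1ccc2c(c1)B(O)OC2)c1ccc(F)cc1` pairs a boron-containing core with a chalcone-like arm that ends in a 4-fluorophenyl ring. Going by the values given here, in a functional assay on HCT-116 cells (Homo sapiens) for cytotoxicity, read by MTT assay, with a stated time of 48 h (on this read-out lower numbers stand for stronger inhibition and higher numbers for weaker inhibition), compound 1 gives 2800 nM, the lower of the two numbers measured so far. Among the compounds with values here, its only measured neighbour is compound 2 `Cc1cccc(C(=O)/C=C/c2ccc3c(c2)B(O)OC3)c1`, which in this assay gives 6700 nM; the change there is a 2.4-fold higher number from compound 1 to compound 2 (0.38 log units; beyond the scatter), a swap of the whole ring on the carbonyl carbon.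

Compound 3 `O=C(O)c1ccc(C(=O)/C=C/c2ccc3c(c2)B(O)OC3)cc1` keeps that ring but changes one substituent on it: carboxy in place of fluoro on an aromatic carbon. Within the data shown here, no measured step covers carboxy in place of fluoro on that ring; the single step from compound 1 to compound 2 shows only that altering this ring moved the number modestly. A step of similar, modest size is therefore expected, with the direction uncertain, leaning toward a weaker result. For compound 3 the estimated step in this assay is a 1.6-fold higher number from compound 1 to compound 3 (0.21 log units; within the scatter). Compound 3 is thus expected to give about 4500 nM, within a range from 1500 nM to 15000 nM.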

Compound 3, half-maximal inhibitory concentration: > 100000 nM
Compound 3 was reported as a limit (the forecaster's own chance of this, stated with the estimate: 5%); middle value at least 22-fold (1.34 log units) away from the limit.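

For compound 3 the reading in this assay is a limit and not a number: the limit of > 100000 nM in this assay, at which 1 of the 3 values shown sits. Even so, one substituent change on the ring, carboxy in place of fluoro on an aromatic carbon para to a large group, gives an at least 35-fold higher number from compound 1 to compound 3 (1.55 log units; beyond the scatter), and that is much larger than the earlier step, a 2.4-fold higher number from compound 1 to compound 2 (0.38 log units; beyond the scatter). This position is therefore not indifferent to what it carries: the earlier pair showed only a modest shift when the ring was altered, whereas this single swap moves the result far more.

The compounds shown do not tell why the number rises so far. They also leave open how an amine or a methyl ester at this same position would behave, and so whether this large step belongs to the carboxy group alone.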